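Bromo in Place of Methyl on Compound 2

The source may report more compounds than this note shows. Statements on the series, on what has been measured and on what is new or still open speak of the compounds shown alone.

compound 1 `COC(=O)[C@@]1(C)CCC=C2[C@@H]1CC[C@@H](C)[C@]2(C)Cc1c[nH]c2ccccc12`: 4500 nM
compound 2 `COC(=O)[C@@]1(C)CCC=C2[C@@H]1CC[C@@H](C)[C@]2(C)Cc1c[nH]c2c(C)cccc12`: 8000 nM

In a functional assay on HBL-100 cells (Homo sapiens) for inhibition, read by sulforhodamine B assay, with a stated time of 48 h (a lower number here means a stronger inhibitor of growth, a higher number a weaker inhibitor of growth), compound 2 gives 8000 nM, the highest of the two numbers, while compound 1 gives 4500 nM. Within the data shown here, the only measured step, a 1.8-fold higher number from compound 1 to compound 2 (0.25 log units; within the scatter), lies within the scatter.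

Compound 3 `COC(=O)[C@@]1(C)CCC=C2[C@@H]1CC[C@@H](C)[C@]2(C)Cc1c[nH]c2c(Br)cccc12` differs from compound 2 by bromo in place of methyl on an aromatic carbon. That one step bears on the same aromatic carbon but exchanges hydrogen for methyl, not methyl for bromo, and it was within the scatter, so for compound 3 no step beyond the scatter is expected in this assay, estimated as no change at the digits printed from compound 2 to compound 3 (within the scatter). Compound 3 is therefore expected at 8000 nM, with a range of 3000 nM to 20000 nM.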

Compound 3, concentration for 50% growth inhibition: 18000 nM
For compound 3 the middle estimate is 2.3-fold (0.35 log units) below the measured one; low and high end bracket the measured number.
By their numbers in this assay, from the lowest: compounds 1 and 2 (each within the scatter of the next); then compound 3.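

Bromo in place of methyl gives a 2.3-fold higher number from compound 2 to compound 3 (0.35 log units; beyond the scatter), and bromo in place of hydrogen gives a 4.0-fold higher number from compound 1 to compound 3 (0.60 log units; beyond the scatter). Both steps are modest, but they show that in this assay growth inhibition does respond to the group on this aromatic carbon, which the step from hydrogen to methyl alone had not shown. Nothing presented here accounts for this weakening. Going by these compounds, whether an amine or a methoxy group on this same carbon would strengthen or further weaken growth inhibition remains open. So does whether bromo on another carbon of this ring would act alike.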